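This account rests on a few compounds, and the source may have more. Where it says the series, first, only, none or still open, it means among the compounds named here.

Measured in a functional assay on A-431 cells (Homo sapiens) for cytotoxicity, read by MTT assay, with a stated time of 24 h; on this read-out higher numbers stand for weaker inhibition and lower numbers for stronger inhibition:
- compound 1 `COc1ccc(/C=C\C(=O)O)c(OCc2cn(-c3ccc(NC(C)=O)cc3)nn2)c1CC=C(C)C`: 23400 nM
- compound 2 `COc1ccc(/C=C\C(=O)O)c(OCc2cn(-c3cccc(C#N)c3)nn2)c1CC=C(C)C`: 22900 nM
- compound 3 `COc1ccc(/C=C\C(=O)O)c(OCc2cn(-c3ccc(CO)cc3)nn2)c1CC=C(C)C`: 16400 nM

Compound 3 cannot be separated from the other two, as all three values lie within the scatter of each other. Compound 4 `COc1ccc(/C=C\C(=O)O)c(OCc2cn(-c3cccnc3Cl)nn2)c1CC=C(C)C`, not yet measured, carries this change: 2-chloropyridin-3-yl in place of 4-(hydroxymethyl)phenyl on an aromatic nitrogen. The measured swaps on the same aromatic nitrogen bear on it, and each stayed within the scatter: a 1.0-fold lower number from compound 1 to compound 2 (0.01 log units; within the scatter), a 1.4-fold lower number from compound 1 to compound 3 (0.15 log units; within the scatter) and a 1.4-fold lower number from compound 2 to compound 3 (0.14 log units; within the scatter). Going by the values given here, no measured compound has a ring with a hetero atom or a chlorine, so this reading is only a loose guide. In this assay the expected step stays within the scatter: a 1.2-fold higher number from compound 3 to compound 4 (0.09 log units; within the scatter). For compound 4 the estimated value is 20000 nM, with an expected range from 11000 nM to 38000 nM.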

Compound 4, half-maximal inhibitory concentration: 32600 nM
For compound 4 the middle estimate is 1.6-fold (0.21 log units) below the measured one, and the stated range covers the measured number.
By their numbers in this assay, from the lowest: compounds 3, 2, 1 and 4 (each within the scatter of the next).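

Going by these compounds alone, on this aromatic nitrogen, 2-chloropyridin-3-yl, the only ring here with a hetero atom and the only group with a chlorine, stays within the scatter of all three earlier groups in this assay (a 2.0-fold higher number from compound 3 to compound 4 (0.30 log units; within the scatter); a 1.4-fold higher number from compound 2 to compound 4 (0.15 log units; within the scatter); a 1.4-fold higher number from compound 1 to compound 4 (0.14 log units; within the scatter)). The position therefore accepts a ring nitrogen and a chlorine with no step beyond the scatter among these four compounds. Nothing measured here accounts for these steps.

From the compounds shown here alone, whether an amine on the ring, or a longer chain in place of the aromatic ring on this nitrogen, would give a step beyond the scatter remains open.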